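Replacing furan-2-yl with 4-chlorophenyl on compound 3

A few compounds are considered here, and "the series" means these few. Any claim that something is new, unique, unknown or untested is made for them only; others in the source may bear on it.

Measured in a functional assay on MCF7 cells (Homo sapiens) for cytotoxicity, read by ELISA, with a stated time of 4 days; a higher number here means a weaker inhibitor, a lower number a stronger inhibitor:
- compound 1 `Cc1ccsc1-c1cc(-c2ccoc2)cc(-c2ccco2)n1`: 18300 nM
- compound 2 `Cc1ccsc1-c1cc(-c2ccoc2)cc(-c2ccc(Cl)cc2)n1`: 20300 nM
- compound 3 `Cc1ccsc1-c1cc(-c2ccc(Cl)o2)cc(-c2ccco2)n1`: 5570 nM

Compound 3 has the lowest number of the three, and its gaps to compound 1 and compound 2 both lie beyond the scatter. Compound 4 `Cc1ccsc1-c1cc(-c2ccc(Cl)o2)cc(-c2ccc(Cl)cc2)n1` keeps the 5-chlorofuran-2-yl group of compound 3 but carries 4-chlorophenyl in place of furan-2-yl on an aromatic carbon, next to the ring nitrogen (4-chlorophenyl in place of furan-2-yl on an aromatic carbon).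

The same exchange has been measured once, as a 1.1-fold higher number from compound 1 to compound 2 (0.05 log units; within the scatter), and that step stays within the scatter. The modest step of a 3.3-fold lower number from compound 1 to compound 3 (0.52 log units; beyond the scatter) bears on the question only indirectly, as it brought in the 5-chlorofuran-2-yl group that compound 4 retains. From the compounds shown here alone, whether the first exchange behaves alike in this new setting is untested, since it rests on a single pair.

The expected change in this assay is therefore none beyond the scatter, with an estimated 1.1-fold higher number from compound 3 to compound 4 (0.05 log units; within the scatter). For compound 4 the expected value is 6200 nM, with an estimated range from 2800 nM to 14000 nM.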

Compound 4, half-maximal inhibitory concentration: 15300 nM
Estimate against measurement, compound 4: 2.5-fold (0.39 log units) below; the measured number lies above the stated range.
By their numbers in this assay, from the lowest: compound 3; then compounds 4, 1 and 2 (each within the scatter of the next).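

In this assay, 4-chlorophenyl in place of furan-2-yl next to the ring nitrogen now gives a change beyond the scatter on the core carrying 5-chlorofuran-2-yl, a 2.7-fold higher number from compound 3 to compound 4 (0.44 log units; beyond the scatter), yet this step cannot be told apart from the earlier one on the furan-3-yl core: the same change on two cores in this assay, a 1.1-fold higher number (0.05 log units; within the scatter) from compound 1 to compound 2 and a 2.7-fold higher number (0.44 log units; beyond the scatter) from compound 3 to compound 4, 2.5-fold (0.39 log units) apart, within the scatter of two such steps. Likewise, 5-chlorofuran-2-yl in place of furan-3-yl gives only a 1.3-fold lower number from compound 2 to compound 4 (0.12 log units; within the scatter) with 4-chlorophenyl present, and this step cannot be told apart from its earlier counterpart either: the same change on two cores in this assay, a 3.3-fold lower number (0.52 log units; beyond the scatter) from compound 1 to compound 3 and a 1.3-fold lower number (0.12 log units; within the scatter) from compound 2 to compound 4, 2.5-fold (0.39 log units) apart, within the scatter of two such steps. The two exchanges therefore cannot be said to depend on each other, although compound 3, with furan-2-yl, remains the lowest of the four.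

From the compounds shown here alone, whether a morpholine in place of furan-2-yl, or a carboxylic acid on the 4-chlorophenyl ring, would move the number remains open. For the compounds shown here, each exchange also rests on only two cores.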